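Sulfanyl to sulfonyl in a bromophenyl enone series

This account rests on a few compounds, and the source may have more. Where it says the series, first, only, none or still open, it means among the compounds named here.

In a functional assay on DU-145 cells (Homo sapiens) for inhibition, read by trypan blue exclusion, with a stated time of 96 h (on this read-out higher numbers stand for weaker inhibition of growth and lower numbers for stronger inhibition of growth), compound 1 `Cc1ccc(S/C(=C/c2c[nH]c3ccccc23)C(=O)c2ccc(Br)cc2)cc1` gives 10000 nM, the only number shown. Compound 2 `Cc1ccc(S/C(=C/c2c(O)cc(O)cc2O)C(=O)c2ccc(Br)cc2)cc1` gives only an assay limit, > 100000 nM. Compound 3 `Cc1ccc(S/C(=C/c2ccc(F)cc2F)C(=O)c2ccc(Br)cc2)cc1` likewise gives only a limit, > 100000 nM. Both measured steps from compound 1 replace the group on a double-bonded chain carbon bound to a double-bonded chain carbon: an at least 10-fold higher number from compound 1 to compound 2 (1.00 log units; beyond the scatter), and an at least 10-fold higher number from compound 1 to compound 3 (1.00 log units; beyond the scatter). Between the two limits, a step that the two limits leave unreadable from compound 2 to compound 3. The relevant evidence is the limit of > 100000 nM in this assay, at which 2 of the 3 values shown sit.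

Compound 4 `Cc1ccc(S(=O)(=O)/C(=C/c2c[nH]c3ccccc23)C(=O)c2ccc(Br)cc2)cc1` changes a different place: (4-methylphenyl)sulfonyl in place of (4-methylphenyl)sulfanyl on a double-bonded chain carbon bound to a carbonyl carbon and a double-bonded chain carbon. Among the compounds with values here, no measured step touches the sulfur, so none bears on this change, and the expected step is within the scatter: a 1.5-fold higher number from compound 1 to compound 4 (0.18 log units; within the scatter). Compound 4 is therefore estimated at 15000 nM, between 4000 nM and 60000 nM.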

Compound 4, concentration for 50% growth inhibition: 10000 nM
Compound 4: the middle estimate sits 1.5-fold (0.18 log units) above what was measured; measured number inside the range.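

The earlier steps shown here changed only the 1H-indol-3-yl group. This one changes the sulfur instead and keeps that group: in this assay, (4-methylphenyl)sulfonyl in place of (4-methylphenyl)sulfanyl gives no change at the digits printed from compound 1 to compound 4 (within the scatter). This holds for this single pair only, and nothing shown gives a reason for the result.

Open, as far as these compounds go, is whether the sulfonyl leaves the read-out unchanged when 2,4-difluorophenyl or 2,4,6-trihydroxyphenyl replaces 1H-indol-3-yl. Also open, from the compounds shown here alone, is how a sulfinyl group or an amine would read at this place.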